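The compounds below may be only part of what the source reports. "The series", "measured", "known", "first", "only" and "open" are said of these compounds alone.

In an ADME assay on microsomes from liver (Canis lupus familiaris) for metabolic stability (a higher number here means faster removal of the compound, a lower number slower removal), compound 2 (`NC1=N[C@@]2(c3cc(NC(=O)c4cnc(OCF)cn4)ccc3F)COCC[C@H]2CC1(F)F`) gives 15.5 mL.min-1.g-1. This number lies within the scatter of the other two measurements: compound 1 (`C[C@@]1(c2cc(NC(=O)c3cnc(OCF)cn3)ccc2F)CCC(F)(F)C(N)=N1`) gives 10.2 mL.min-1.g-1 and compound 3 (`C[C@H]1C[C@H]2CC(F)(F)C(N)=N[C@@]2(c2cc(NC(=O)c3cnc(OCF)cn3)ccc2F)CO1`) gives 18.6 mL.min-1.g-1. Compound 4 (`NC1=N[C@@]2(c3cc(NC(=O)c4cnc(OCF)cn4)ccc3F)CO[C@@H](CF)C[C@H]2CC1(F)F`) has not yet been measured. It differs from compound 2 by one change, (fluoromethyl in place of hydrogen on a saturated ring carbon), with fluoromethyl in place of hydrogen on a saturated ring carbon, next to the ring oxygen. Within the data shown here, the only measured step of this kind is methyl in place of hydrogen on a saturated ring carbon, which gave a 1.2-fold higher number from compound 2 to compound 3 (0.08 log units; within the scatter). On that single step, no change beyond the scatter is expected in this assay, and the direction stays uncertain. The expected result is a 1.1-fold higher number from compound 2 to compound 4 (0.04 log units; within the scatter). For compound 4 the estimated value is 17 mL.min-1.g-1, with an expected range from 9 mL.min-1.g-1 to 32 mL.min-1.g-1.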

Compound 4, intrinsic clearance in microsomes: < 7.7 mL.min-1.g-1
Compound 4 was reported as a limit; the forecaster's own chance of this, stated with the estimate: 2%; middle value at least 2.2-fold (0.34 log units) away from the limit.
By their numbers in this assay, from the lowest: compounds 1, 2 and 3 (each within the scatter of the next). At a limit, below all of these: compound 4.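

In this assay, the result for compound 4 is a limit and not a number: the limit of < 7.7 mL.min-1.g-1 in this assay, at which 1 of the 4 values shown sits. On the saturated ring carbon next to the ring oxygen, fluoromethyl in place of hydrogen gives an at least 2.0-fold lower number from compound 2 to compound 4 (0.30 log units; that floor lies within the scatter). Fluoro in place of hydrogen on the methyl group gives an at least 2.4-fold lower number from compound 3 to compound 4 (0.38 log units; beyond the scatter), the only step shown that is beyond the scatter, so a group at this position can shift the number although methyl alone did not. From the compounds shown here alone, how far compound 4 lies past its limit remains open. Also open, going by these compounds, is whether hydroxymethyl, methoxymethyl or ethyl at this position would give a similar result.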